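One Inverted Stereocentre: From Compound 3 to Compound 4

A few compounds are considered here, and "the series" means these few. Any claim that something is new, unique, unknown or untested is made for them only; others in the source may bear on it.

- compound 1 `CN[C@@H](C)c1ccc(N2CC[C@H](NS(=O)(=O)c3ccc4cc(Cl)ccc4c3)C2=O)c(F)c1`: 1.6 mL/min/kg
- compound 2 `CN(C)C1CCc2cc(N3CC[C@H](NS(=O)(=O)/C=C/c4ccc(Cl)s4)C3=O)ccc21`: 9.5 mL/min/kg
- compound 3 `CN(C)[C@H]1CCc2cc(N3CC[C@H](NS(=O)(=O)c4ccc5cc(Cl)ccc5c4)C3=O)ccc21`: 6 mL/min/kg

All three compounds were measured in an in vivo ADME assay on the whole organism (plasma, strain Sprague-Dawley) for pharmacokinetics, with Rattus norvegicus as the target; on this read-out lower numbers stand for slow clearance and higher numbers for fast clearance. There, compound 3 gives 6 mL/min/kg. That number lies within the usual scatter of compound 2 at 9.5 mL/min/kg, so the two cannot be told apart. It stands above compound 1 at 1.6 mL/min/kg, a gap beyond the scatter.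

The next compound to be tested is compound 4 `CN(C)[C@@H]1CCc2cc(N3CC[C@H](NS(=O)(=O)c4ccc5cc(Cl)ccc5c4)C3=O)ccc21`, the close relative of compound 3. The structural difference is simple to state: the two compounds have the same atoms and bonds and differ only in configuration as drawn: 1 of 2 stereo elements differ; a stereocentre at a saturated ring carbon is drawn S in compound 3 and R in compound 4. Nothing enters or leaves, and only the drawing of that saturated ring carbon changes.

Among the compounds with values here, no two measured compounds differ in just one place, so the data do not show what this inversion does in this assay. The best available anchor is compound 3 itself at 6 mL/min/kg, and no direction can be favoured from it. The expected result is none beyond the scatter, and the estimated step is a 1.1-fold higher number from compound 3 to compound 4 (0.03 log units; within the scatter). For compound 4 the expected clearance is 6.5 mL/min/kg, with an estimated range of 2.5 mL/min/kg to 16 mL/min/kg.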

Compound 4, clearance: 7.6 mL/min/kg
For compound 4 the middle estimate is 1.2-fold (0.07 log units) below the measured one, within the range that was stated.
By their numbers in this assay, from the lowest: compound 1; then compounds 3, 4 and 2 (each within the scatter of the next).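

In this assay, the inversion of the saturated ring carbon from S to R gives the first reading of a single change among the compounds shown, and it comes to a 1.3-fold higher number from compound 3 to compound 4 (0.10 log units; within the scatter). For this stereocentre, then, the two drawn configurations cannot be told apart by clearance in the rat, and neither form can be called the more slowly cleared. The reading can be tied to this one stereocentre alone, because nothing else separates the two structures: the fact that compounds 3 and 4 differ only in the configuration as drawn

Going by these compounds, what stays open is whether the same insensitivity would hold if the other stereo element were inverted, or if the stereocentre were inverted on a compound carrying a different sulfonyl group, since this single pair speaks only for the one shared structure around it. It also leaves open how clearance would respond if the dimethylamino group gave way to a primary amine or a carboxylic acid, and whether the configuration would then count for more than it does here.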